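A Dimethylamino Aryl Ether Follows Three Measured Analogues

The source may report more compounds than this note shows. Statements on the series, on what has been measured and on what is new or still open speak of the compounds shown alone.

The series shares one core and varies the aryl group on the ether oxygen. Compound 1 `CC[C@@H]1/C=C(\C)C[C@H](C)C[C@H](OC)[C@H]2O[C@@](O)(C(=O)C(=O)N3CCCC[C@H]3C(=O)O[C@H](/C(C)=C/[C@@H]3CC[C@@H](Oc4ccc(O)cc4)[C@H](OC)C3)[C@H](C)[C@@H](O)CC1=O)[C@H](C)C[C@@H]2OC` gives 0.8 nM in a functional assay on cells for inhibition, with Murine T-cell line (Mus musculus) as the target; a lower number here means a stronger inhibitor, a higher number a weaker inhibitor. Compound 2 `CC[C@@H]1/C=C(\C)C[C@H](C)C[C@H](OC)[C@H]2O[C@@](O)(C(=O)C(=O)N3CCCC[C@H]3C(=O)O[C@H](/C(C)=C/[C@@H]3CC[C@@H](Oc4ccc(SC)cc4)[C@H](OC)C3)[C@H](C)[C@@H](O)CC1=O)[C@H](C)C[C@@H]2OC` gives 2.6 nM in this assay, and compound 3 `CC[C@@H]1/C=C(\C)C[C@H](C)C[C@H](OC)[C@H]2O[C@@](O)(C(=O)C(=O)N3CCCC[C@H]3C(=O)O[C@H](/C(C)=C/[C@@H]3CC[C@@H](Oc4cccc(C)c4)[C@H](OC)C3)[C@H](C)[C@@H](O)CC1=O)[C@H](C)C[C@@H]2OC` gives 5.4 nM. Compound 3 thus stands highest of the three numbers: it lies a 2.1-fold higher number from compound 2 to compound 3 (0.32 log units; beyond the scatter) and a 6.8-fold higher number from compound 1 to compound 3 (0.83 log units; beyond the scatter), both beyond the scatter.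

Compound 4 `CC[C@@H]1/C=C(\C)C[C@H](C)C[C@H](OC)[C@H]2O[C@@](O)(C(=O)C(=O)N3CCCC[C@H]3C(=O)O[C@H](/C(C)=C/[C@@H]3CC[C@@H](Oc4ccc(N(C)C)cc4)[C@H](OC)C3)[C@H](C)[C@@H](O)CC1=O)[C@H](C)C[C@@H]2OC` carries the change (4-(dimethylamino)phenyl in place of 3-methylphenyl on an oxygen on a saturated carbon). The two steps that bear on it both replace a 4-substituted phenyl with 3-methylphenyl: 4-hydroxyphenyl to 3-methylphenyl raises the number by a 6.8-fold higher number from compound 1 to compound 3 (0.83 log units; beyond the scatter), and 4-(methylsulfanyl)phenyl to 3-methylphenyl raises it by a 2.1-fold higher number from compound 2 to compound 3 (0.32 log units; beyond the scatter). Going the other way, from 3-methylphenyl back to a 4-substituted phenyl, a lower number is therefore expected for compound 4, of a size between those two steps, since no 4-(dimethylamino)phenyl has been measured here and the two 4-substituted analogues themselves differ by a 3.3-fold higher number from compound 1 to compound 2 (0.51 log units; beyond the scatter).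

In this assay compound 4 is expected at about 2 nM, with a plausible range from 0.8 nM to 5 nM. That estimate corresponds to an expected step of a 2.7-fold lower number from compound 3 to compound 4 (0.43 log units; beyond the scatter).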

Compound 4, half-maximal inhibitory concentration: 1.1 nM
Beside the measured number, compound 4's estimate is 1.8-fold (0.26 log units) above it, within the range that was stated.
By their numbers in this assay, from the lowest: compounds 1 and 4 (each within the scatter of the next); then compound 2; then compound 3.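

In this assay, the step from 3-methylphenyl to 4-(dimethylamino)phenyl on the ether oxygen gives a 4.9-fold lower number from compound 3 to compound 4 (0.69 log units; beyond the scatter), which shows that a nitrogen-bearing group can bring this position back to the low end of the series. Dimethylamino in place of methylsulfanyl on the aromatic carbon gives a 2.4-fold lower number from compound 2 to compound 4 (0.37 log units; beyond the scatter), while dimethylamino in place of hydroxy gives a 1.4-fold higher number from compound 1 to compound 4 (0.14 log units; within the scatter), which is within the scatter, so compound 1 and compound 4 cannot be ordered, and compound 2 shows that not every 4-substituted phenyl group reaches their level. Nothing available here gives a reason for these differences.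

The step from compound 3 changes both the group and where it sits on the phenyl ring, and the compounds shown do not separate those two changes. A 4-methylphenyl or a 3-(dimethylamino)phenyl group on the same oxygen would separate them, while a 4-aminophenyl or 4-carboxyphenyl group would show how far the low numbers extend beyond hydroxy and dimethylamino.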